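Swapping 1-hydroxyethyl for methoxymethyl on the shared core

The source may hold more compounds than are shown below. What is called first, only, known or untested is meant among the compounds shown, and "the series" means these compounds.

Compound 1 `OCCc1cn(Cc2ccc(Cl)cc2)c2ccccc12`: > 31600 nM (a limit)
Compound 2 `CC(O)c1cn(Cc2ccc(Cl)cc2)c2ccccc12`: 25100 nM

In a functional assay on NCI-H460 cells (Homo sapiens) for cytotoxicity, read by sulforhodamine B assay, with a stated time of 3 days (a lower number here means a stronger inhibitor, a higher number a weaker inhibitor), compound 1 gives > 31600 nM, which is a limit and not a number. For the measured compounds named here, compound 2, at 25100 nM, holds the only true number so far. Compound 3 `COCc1cn(Cc2ccc(Cl)cc2)c2ccccc12` changes one group of compound 2: methoxymethyl in place of 1-hydroxyethyl on an aromatic carbon, with methoxymethyl in place of 1-hydroxyethyl on an aromatic carbon. Going by the values given here, the one measured step, an at least 1.2-fold lower number from compound 1 to compound 2 (0.10 log units; that floor lies within the scatter), changed the group at this same place, and its size stays within the scatter. No step beyond the scatter is therefore expected in this assay. Compound 3 is expected near 23000 nM, within an estimated range of 11000 nM to 31600 nM. This estimate means an expected 1.1-fold lower number from compound 2 to compound 3 (0.04 log units; within the scatter), which is no real change.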

Compound 3, half-maximal inhibitory concentration: 1990 nM
The estimate for compound 3 lay 12-fold (1.06 log units) above the measured number, and the stated range ends above it.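

In this assay this position, two ring bonds from the ring nitrogen, proves sensitive: the same atoms joined differently give a 13-fold lower number from compound 2 to compound 3 (1.10 log units; beyond the scatter), a change far larger than any seen before. Methoxymethyl has 0 hydrogen-bond donors where 1-hydroxyethyl has 1, though these compounds cannot show whether that difference is what matters. The other step, an at least 15-fold lower number from compound 1 to compound 3 (1.20 log units; beyond the scatter), rests on a limit and not a true number: the limit of > 31600 nM in this assay, at which 1 of the 3 values shown sits. Still open, from the compounds shown here alone, is whether a longer chain such as ethoxymethyl, or an amine such as dimethylaminomethyl, would hold this lower number at the same position.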